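This account rests on a few compounds, and the source may have more. Where it says the series, first, only, none or still open, it means among the compounds named here.

Three compounds built on a shared core were compared in an assay on isolated protein for inhibition of Rho-associated protein kinase 2 (Homo sapiens), read by scintillation counting, radiometric assay and 33P incorporation, with a stated time of 40 min, in the presence of a further agent that is not named here; a lower number here means a stronger inhibitor, a higher number a weaker inhibitor. Compound 1 `COc1cc(OCC(=O)Nc2cccc(NC(=O)c3ccc(N(C)C)cc3)c2)ccc1C=O` gives 306 nM in this assay. Compound 2 `O=C(COc1ccc2c(=O)ccoc2c1)Nc1cccc(NC(=O)c2ccc(Br)cc2)c1` gives 49 nM in this assay. Compound 3 `CCOc1ccc(C(=O)Nc2cccc(NC(=O)COc3ccc4c(=O)ccoc4c3)c2)cc1` gives 9 nM in this assay, the lowest of the three numbers; the nearest is compound 2, and compound 1 lies furthest away. Among the measured compounds shown here, the only pair differing in one place is compound 2 against compound 3, with a 5.4-fold lower number from compound 2 to compound 3 (0.74 log units; beyond the scatter), where ethoxy replaced bromo on an aromatic carbon.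

Compound 4 `O=C(COc1ccc2c(=O)ccoc2c1)Nc1cccc(NC(=O)c2ccc(C(=O)O)cc2)c1` differs from compound 3 by carboxy in place of ethoxy on an aromatic carbon. For the measured compounds named here, the step of a 5.4-fold lower number from compound 2 to compound 3 (0.74 log units; beyond the scatter) touches the same aromatic carbon, but it exchanged bromo for ethoxy, not ethoxy for carboxy, so no measured step shows what carboxy does here. The expectation is therefore uncertain: a step of modest size, more likely toward a higher number than a lower one, is expected. Compound 4 is estimated at 40 nM, within a range of 8 nM to 200 nM, which corresponds to an expected step of a 4.4-fold higher number from compound 3 to compound 4 (0.65 log units; beyond the scatter).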

Compound 4, half-maximal inhibitory concentration: 2030 nM
The estimate for compound 4 lay 51-fold (1.71 log units) below the measured number, and the stated range ends below it.
By their numbers in this assay, from the lowest: compound 3; then compound 2; then compound 1; then compound 4.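

Placing carboxy on this aromatic carbon gives the largest change seen at this position in this assay, with a 230-fold higher number from compound 3 to compound 4 (2.35 log units; beyond the scatter) and a 41-fold higher number from compound 2 to compound 4 (1.62 log units; beyond the scatter) as the two steps. The earlier step, a 5.4-fold lower number from compound 2 to compound 3 (0.74 log units; beyond the scatter), was modest, so the new steps show that this one carbon can shift the number far more than that exchange suggested, and that the group placed here can weaken inhibition as well as strengthen it. Among the compounds shown here, no measurement at hand bears on why carboxy raises the number so far.

The compounds shown leave open whether a methyl ester or a primary amide on the same carbon would raise the number as carboxy does. They also leave open whether a longer chain such as propoxy would improve on ethoxy or fall short of it.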